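Adding a propoxy group to a low-cytotoxicity scaffold

The source may hold more compounds than are shown below. What is called first, only, known or untested is meant among the compounds shown, and "the series" means these compounds.

compound 1 `Cc1ccc2cc(CN(Cc3ccc(F)cc3)Cc3ccc(C(C)(C)C)cc3)c(=O)[nH]c2c1` — > 33000 nM
compound 2 `Cc1ccc2[nH]c(=O)c(CN(Cc3ccccc3)Cc3ccc(C(C)(C)C)cc3)cc2c1` — > 5000 nM
compound 3 `Cc1ccc2[nH]c(=O)c(CN(Cc3ccc(F)cc3)Cc3cccc4ccccc34)cc2c1` — > 5000 nM

Of the compounds shown here, three have been tested in a toxicity assay on MDCK cells (Canis lupus familiaris) for cytotoxicity, read by crystal violet staining, with a stated time of 48 h; on this read-out lower numbers stand for higher toxicity in this test and higher numbers for lower toxicity in this test. Compound 1 gives > 33000 nM, which is a limit of the assay rather than a number. Compound 2 gives > 5000 nM, again a limit. Compound 3 gives > 5000 nM, also a limit. Compound 2 thus sits at the limit of > 5000 nM in this assay, at which 2 of the 3 values shown sit. Every value shown is a limit. Within the data shown here, none of the three compounds can be placed above or below another, and no step between measured compounds is available.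

Compound 4 `CCCOc1ccc(CN(Cc2ccc(C(C)(C)C)cc2)Cc2cc3cc(C)ccc3[nH]c2=O)cc1` has not yet been measured. It differs from compound 2 in one place: propoxy in place of hydrogen on an aromatic carbon. Among the measured compounds, changes in the benzyl groups around the amine have left all values at a limit, and the propoxy group in place of hydrogen is expected to behave the same way. The step that the limit leaves unreadable from compound 2 to compound 4 is therefore expected to stay within the scatter, in no particular direction. Compound 4 is estimated at 20000 nM, with a range from 5000 nM to 80000 nM, and it is quite likely that only a limit will be reported once more.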

Compound 4, half-maximal cytotoxic concentration: > 5000 nM
Compound 4 ended at the assay's limit (the forecaster's own chance of this, stated with the estimate: 70%); the middle value is on the limit's open side.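

Compound 2 and compound 4 both stand at a limit in this assay, so no step between them can be read: the limit of > 5000 nM in this assay, at which 3 of the 4 values shown sit.

The compounds shown leave open whether propoxy in place of hydrogen changes the half-maximal cytotoxic concentration at all, and how any of the four compounds ranks against another.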